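Amide aryl swap on the quinoline-free core: compound 4

A few compounds are considered here, and "the series" means these few. Any claim that something is new, unique, unknown or untested is made for them only; others in the source may bear on it.

Compound 1 `CCN1CCN(c2cc(C)c3cc(NC(=O)c4ccc(Br)cc4)ccc3n2)CC1` is one of three measured entries in a functional assay on SK-BR-3 cells (Homo sapiens) for antiproliferative activity, read by MTT assay, with a stated time of 72 h; a lower number here means a stronger inhibitor, a higher number a weaker inhibitor; in this assay compound 1 gives 6310 nM. Compound 2 `Cc1cc(N2CCN(C)CC2)nc2ccc(NC(=O)c3ccc(Cl)c(Cl)c3)cc12` gives 6320 nM, and compound 3 `CCN(CC)CCNc1cc(C)c2cc(NC(=O)c3ccc(Cl)c(Cl)c3)ccc2n1` gives 3710 nM; all three values lie within the scatter of one another, so no order among them can be read. Among the measured compounds shown here, the only measured step, a 1.7-fold lower number from compound 2 to compound 3 (0.23 log units; within the scatter), concerns the basic amine on the aromatic carbon, not the amide. Compound 4 `CCN1CCN(c2cc(C)c3cc(NC(=O)c4ccco4)ccc3n2)CC1` differs from compound 1 at the amide: furan-2-yl in place of 4-bromophenyl on a carbonyl carbon. For the measured compounds named here, no measured step bears on this position, so nothing predicts a change beyond the scatter; the expected step is a 1.3-fold higher number from compound 1 to compound 4 (0.10 log units; within the scatter). Compound 4 is therefore estimated at 8000 nM, with a range of 3000 nM to 25000 nM.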

Compound 4, half-maximal inhibitory concentration: 37500 nM
Compound 4: the middle estimate sits 4.7-fold (0.67 log units) below what was measured; the whole stated range lies below it.
By their numbers in this assay, from the lowest: compounds 3, 1 and 2 (each within the scatter of the next); then compound 4.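

Among the compounds shown here, the amide aryl group is the first position to show a step beyond the scatter in this assay: furan-2-yl in place of 4-bromophenyl on a carbonyl carbon gives a 5.9-fold higher number from compound 1 to compound 4 (0.77 log units; beyond the scatter). For the compounds shown here, the only earlier step, at the amine on an aromatic carbon, stayed within the scatter, so this position is not indifferent to change. No measured evidence accounts for this step.

Still open, going by these compounds, is whether the rise follows from losing 4-bromophenyl or from introducing furan-2-yl; a plain phenyl or a thiophen-2-yl on the same carbonyl would help separate the two. On these data alone, whether the step carries over to the (2-(diethylamino)ethyl)amino series also remains unknown.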